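Swapping phenyl for indolyl: does liver stability hold?

The source may report more compounds than this note shows. Statements on the series, on what has been measured and on what is new or still open speak of the compounds shown alone.

Measured so far:
- compound 1, `COc1ccc(-c2c(C)oc3c(N4CC[C@@H](NC(C)=O)C4)cc(C)nc23)cc1OC`: > 95%
- compound 2, `CC(=O)N[C@@H]1CCN(c2cc(C)nn3c(-c4ccccc4)c(C)nc23)C1`: > 95%

In an ADME assay on microsomes from liver (Homo sapiens) for metabolic stability, read by LC-MS, with NADPH named in the record, with a stated time of 60 min, tested at 1 uM, in the absence of a further agent (a lower number here means that less of the compound is left, a higher number that more of the compound is left), compound 1 gives > 95%, which is a limit of the assay rather than a number. In this assay compound 2 likewise gives > 95%, again a limit and not a number. Both results sit at the limit of > 95% in this assay, at which 2 of the 2 values shown sit, so compound 2 stands at the top of what the assay can report, alongside compound 1.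

The next compound, compound 3, `CC(=O)N[C@@H]1CCN(c2cc(C)nn3c(-c4ccc5cc[nH]c5c4)c(C)nc23)C1`, is not yet measured. It differs from compound 2 in one place: 1H-indol-6-yl in place of phenyl on an aromatic carbon.

Within the data shown here, no step between measured compounds is available, so the size of the change can only be estimated. Compound 3 is expected to give 90%, within a range of 72% to 99%. The step of a number at least 5 percentage points lower from compound 2 to compound 3 (that floor lies within the scatter) is expected to be small, at most a little beyond the usual scatter.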

Compound 3, percent of the compound remaining: > 95%
Compound 3: a limit, no number; the forecaster's own chance of this, stated with the estimate: 50%; at least 5 percentage points between middle value and limit.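

In this assay compound 3 gives > 95%, a limit and not a number. Compound 2 also stands at a limit, so no step between compound 2 and compound 3 can be read: the limit of > 95% in this assay, at which 3 of the 3 values shown sit.

The compounds shown leave open whether 1H-indol-6-yl in place of phenyl changes how much compound is left at all.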